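A few compounds are considered here, and "the series" means these few. Any claim that something is new, unique, unknown or untested is made for them only; others in the source may bear on it.

Of the compounds shown here, three of one series have been measured in a functional assay on MCF7 cells (Homo sapiens), tested at 2.5 uM; a lower number here means a stronger effect, a higher number a weaker effect of the compound at the concentration tested. Compound 1 `C=CCOc1c(C)c(C)c2c(c1C)CCC(C)(COc1ccc(/C=C3\SC(=O)NC3=O)cc1OCC)O2` gives 107% in this assay. Compound 2 `CCOc1cc(/C=C2\SC(=O)NC2=O)ccc1OCC1(C)CCc2c(C)c(OCC=C(C)C)c(C)c(C)c2O1` carries 2-methylprop-1-en-1-yl in place of vinyl on a saturated chain carbon bound to an oxygen on an aromatic ring relative to compound 1, and in this assay compound 2 gives 107%, so that no change at the digits printed from compound 1 to compound 2 (within the scatter). Compound 3 `C=CCOc1c(C)c(C)c2c(c1C)CCC(C)(COc1ccc(/C=C3\SC(=O)NC3=O)cc1Br)O2` differs from compound 1 by bromo in place of ethoxy on an aromatic carbon; in this assay compound 3 gives 102%, and a number 5 percentage points lower from compound 1 to compound 3 (within the scatter). All three numbers therefore lie within the scatter of one another, and none of these compounds can be set apart from the others on this evidence.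

Compound 4 `CC(C)=CCOc1c(C)c(C)c2c(c1C)CCC(C)(COc1ccc(/C=C3\SC(=O)NC3=O)cc1Br)O2` has not yet been measured. It differs from compound 3 by 2-methylprop-1-en-1-yl in place of vinyl on a saturated chain carbon bound to an oxygen on an aromatic ring. Among the measured compounds shown here, this is the same change as the one from compound 1 to compound 2, now made on the second core; the two cores differ by bromo in place of ethoxy on an aromatic carbon, and the place of the change reads the same in both cases. Because no change at the digits printed from compound 1 to compound 2 (within the scatter) the same kind of outcome is expected here, no change at the digits printed from compound 3 to compound 4 (within the scatter). Since compound 3 gives 102% in this assay, compound 4 is estimated to give 102% in this assay, with a likely range from 92% to 112%.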

Compound 4, a percentage reported as activity, at one concentration (the size of the read-out at that concentration, not a potency): 96%
Compound 4: the middle estimate sits 6 percentage points above what was measured; low and high end bracket the measured number.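

In this assay, putting (3-methylbut-2-en-1-yl)oxy in place of allyloxy on the bromo compounds gives a number 6 percentage points lower from compound 3 to compound 4 (within the scatter), and this step does not differ from the one made on the ethoxy compounds: the same change on two cores in this assay, no change at the digits printed (within the scatter) from compound 1 to compound 2 and a number 6 percentage points lower (within the scatter) from compound 3 to compound 4, 6 percentage points apart, within the scatter of two such steps. Bromo in place of ethoxy, now carried on the compounds with the longer chain, gives a number 11 percentage points lower from compound 2 to compound 4 (beyond the scatter), a modest step that also does not differ from its earlier counterpart: the same change on two cores in this assay, a number 5 percentage points lower (within the scatter) from compound 1 to compound 3 and a number 11 percentage points lower (beyond the scatter) from compound 2 to compound 4, 6 percentage points apart, within the scatter of two such steps. Both changes therefore read alike on the two cores, but this rests on a single pair of steps for each change, and the step beyond the scatter has a counterpart within it, so the four compounds show neither a firm effect of either change nor any rule for other cores in this series.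

The compounds shown leave open how a saturated chain such as butyl would read in place of 3-methylbut-2-en-1-yl, and how chloro or an amine would read in place of bromo. They also leave open whether the agreement between the steps would hold for groups that move the read-out in this assay well beyond the scatter.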